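Series notes: ureido to methyl(oxan-4-yl)amino

This account rests on a few compounds, and the source may have more. Where it says the series, first, only, none or still open, it means among the compounds named here.

- Compound 1 `NCCCCN(C[C@@H]1Cc2cccnc2CN1)[C@H]1CCCc2cccnc21` in an ADME assay on microsomes from liver (Homo sapiens) for metabolic stability, using NADPH, with a stated time of 10 min (on this read-out higher numbers stand for a more stable compound and lower numbers for a less stable compound), gives 92%
- Compound 2 `NCCCCN(C[C@H]1Cc2nccnc2CN1)[C@H]1CCCc2cccnc21` gives 84%
- Compound 3 `NC(=O)NCCCCN(C[C@H]1Cc2ncccc2CN1)[C@H]1CCCc2cccnc21` gives 91%

Compound 3 at 91% stands inside the scatter of both other compounds, and all three values form one group at the high end of this assay with no separation among them. Within the data shown here, no two measured compounds differ in one place only, so the series offers no measured step to read across.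

The next structure is compound 4 `CN(CCCCN(C[C@H]1Cc2ncccc2CN1)[C@H]1CCCc2cccnc21)C1CCOCC1` and it keeps the core of compound 3. The change is methyl(oxan-4-yl)amino in place of ureido on a saturated chain carbon, four bonds along the chain from an amine nitrogen and nothing else in the structure moves. Among the measured compounds shown here, the entering group has no counterpart among the measured compounds, so any expectation here is weakly supported.

Compound 3 at 91% leaves little room upward, so movement is expected mainly in one direction. The estimated step of a number 15 percentage points lower from compound 3 to compound 4 (beyond the scatter) is a downward one, expected to lie beyond the scatter, though the uncertainty is wide and a result within the scatter remains possible. For compound 4 the expected value is 76% with an estimated range from 52% to 92% in this estimate.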

Compound 4, percent of the compound remaining: 100%
Beside the measured number, compound 4's estimate is 24 percentage points below it; measured number outside the range, above it.
By their numbers in this assay, from the lowest: compounds 2, 3, 1 and 4 (each within the scatter of the next, the first and the last beyond it).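

In this assay, among these compounds, methyl(oxan-4-yl)amino in place of ureido on a saturated chain carbon, four bonds along the chain from an amine nitrogen, gives a number 9 percentage points higher from compound 3 to compound 4 (within the scatter) and so supplies the first measured single-place step. At this position, the exchange of ureido, with 4 heavy atoms and 2 hydrogen-bond donors, for a group with 8 heavy atoms, one six-membered non-aromatic ring and 0 hydrogen-bond donors produces no difference that can be told from the scatter of this read-out. No measured evidence is available to explain this outcome.

With compound 4 at 100%, the top of this read-out, and compound 3 at 91%, the pair leaves little room to show any separation in stability between these two groups. As far as these compounds go, it remains open whether a primary amine, a carboxylic acid, a morpholine or a longer chain at the same place would also stay within the scatter of compound 3, and whether the same exchange would read the same way on another core.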